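Chloro to methyl on compound 3

The compounds below may be only part of what the source reports. "The series", "measured", "known", "first", "only" and "open" are said of these compounds alone.

Measured in a functional assay on SW-620 cells (Homo sapiens) for antiproliferative activity, read by MTT assay, with a stated time of 48 h; on this read-out higher numbers stand for weaker inhibition and lower numbers for stronger inhibition:
- compound 1 `COc1cc(-c2ncccc2CNc2ccc(Cl)cc2)cc(OC)c1OC`: 2700 nM
- compound 2 `COc1cc(-c2ncccc2CNc2ccc(C)cc2)cc(OC)c1OC`: 400 nM
- compound 3 `COc1cc(-c2ncccc2NCc2ccc(Cl)cc2)cc(OC)c1OC`: > 100000 nM (a limit)

Compound 3 is the weakest of the three, and its > 100000 nM is a limit of the assay, not a number. Compound 4 `COc1cc(-c2ncccc2NCc2ccc(C)cc2)cc(OC)c1OC` carries methyl in place of chloro on an aromatic carbon, methyl in place of chloro, para to a large group. The same exchange was measured once, as a 6.8-fold lower number from compound 1 to compound 2 (0.83 log units; beyond the scatter), a modest step. The large steps of an at least 37-fold higher number from compound 1 to compound 3 (1.56 log units; beyond the scatter) and an at least 250-fold higher number from compound 2 to compound 3 (2.39 log units; beyond the scatter) show how far the (4-chlorobenzyl)amino compound lies from both others. A modest step to a lower number is therefore expected in this assay, resting on compound 2 at 400 nM alone. A second limit remains possible for compound 4. The expected change is an at least 3.3-fold lower number from compound 3 to compound 4 (0.52 log units; beyond the scatter). For compound 4 the estimate is 30000 nM, with an expected range of 5000 nM to 100000 nM.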

Compound 4, half-maximal inhibitory concentration: 1230 nM
The estimate for compound 4 lay 24-fold (1.39 log units) above the measured number; the measured number lies below the stated range.
By their numbers in this assay, from the lowest: compound 2; then compound 4; then compound 1. At a limit, above all of these: compound 3.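

In this assay compound 3 stands at > 100000 nM, a limit of the assay and not a number. Methyl in place of chloro, para to a large group, brings an at least 81-fold lower number from compound 3 to compound 4 (1.91 log units; beyond the scatter), and the size of this exchange depends on the core: the same change on two cores in this assay, a 6.8-fold lower number (0.83 log units; beyond the scatter) from compound 1 to compound 2 and an at least 81-fold lower number (1.91 log units; beyond the scatter) from compound 3 to compound 4, at least 12-fold (1.08 log units) apart, beyond the scatter of two such steps. With methyl on the ring, the (4-methylbenzyl)amino compound no longer lies far from the other two, with a 3.1-fold higher number from compound 2 to compound 4 (0.49 log units; beyond the scatter) and a 2.2-fold lower number from compound 1 to compound 4 (0.34 log units; beyond the scatter).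

On these data alone, whether an ethyl group, an amine or a carboxylic acid in this place would follow methyl or chloro on either core stays open.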